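The source may hold more compounds than are shown below. What is called first, only, known or untested is meant among the compounds shown, and "the series" means these compounds.

In a functional assay on HepG2 cells (Homo sapiens) for inhibition, read by MTT assay, with a stated time of 24 h (a lower number here means a stronger inhibitor, a higher number a weaker inhibitor), compound 3 (`COc1ccccc1-n1cc(CN2C(=O)C[C@@H]3CC[C@@]2(C)C3(C)C)nn1`) gives 110 nM. Compound 1 (`CC1(C)[C@H]2CC[C@]1(C)N(Cc1cn(-c3cccc(F)c3)nn1)C(=O)C2`) gives 80 nM, and the step, a 1.4-fold higher number from compound 1 to compound 3 (0.14 log units; within the scatter), leaves the two level. Compound 2 (`CC1(C)[C@H]2CC[C@]1(C)N(Cc1cn(-c3ccc(C#N)cc3)nn1)C(=O)C2`) gives 50 nM, and the step, a 2.2-fold higher number from compound 2 to compound 3 (0.34 log units; beyond the scatter), is the only one that clears the scatter. Compound 4 (`CC1(C)[C@H]2CC[C@]1(C)N(Cc1cn(-c3ccccc3)nn1)C(=O)C2`) has hydrogen in place of methoxy on an aromatic carbon, ortho to a large group (hydrogen in place of methoxy on an aromatic carbon). Going by the values given here, no measured step makes this exact change. The closest evidence is these swaps of the group on the aromatic nitrogen, together with a 1.6-fold lower number from compound 1 to compound 2 (0.20 log units; within the scatter), so only a small shift toward a lower number is expected in this assay, probably none beyond the scatter. The expected step is a 1.2-fold lower number from compound 3 to compound 4 (0.09 log units; within the scatter). Compound 4 is estimated at 90 nM, with an expected range of 35 nM to 220 nM.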

Compound 4, half-maximal inhibitory concentration: 90 nM
The estimate for compound 4 equals the measured number at the digits printed; low and high end bracket the measured number.
By their numbers in this assay, from the lowest: compounds 2, 1, 4 and 3 (each within the scatter of the next, the first and the last beyond it).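

In this assay the plain phenyl of compound 4 shows that no substituent on this aromatic ring is needed: hydrogen replaces methoxy (a 1.2-fold lower number from compound 3 to compound 4 (0.09 log units; within the scatter)), fluoro (a 1.1-fold higher number from compound 1 to compound 4 (0.05 log units; within the scatter)) and cyano (a 1.8-fold higher number from compound 2 to compound 4 (0.26 log units; within the scatter)). Methoxy, fluoro and cyano therefore each stand level with hydrogen, and the one step beyond the scatter, between compound 2 and compound 3, is not a step away from the phenyl itself. No evidence at hand explains this flat response.

Still open, going by these compounds, is whether an amine or a carboxylic acid on this phenyl would move the number beyond the scatter.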